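Swapping an ether for an amine on a longer urea tail

The source may report more compounds than this note shows. Statements on the series, on what has been measured and on what is new or still open speak of the compounds shown alone.

The compounds share one core and differ only in the side chain hanging from a urea group. Compound 1 `COCCNC(=O)Nc1cc2c(Nc3ccc(F)c(Cl)c3)ncnc2cc1O[C@H]1CCOC1` gives 387 nM in a functional assay on A-431 cells (Homo sapiens) for antiproliferative activity, read by sulforhodamine B assay, with a stated time of 72 h; a higher number here means a weaker inhibitor, a lower number a stronger inhibitor. Compound 2 `O=C(NCCN1CCCC1)Nc1cc2c(Nc3ccc(F)c(Cl)c3)ncnc2cc1O[C@H]1CCOC1` gives 247 nM, and the move a 1.6-fold lower number from compound 1 to compound 2 (0.20 log units; within the scatter) shows that exchanging the ether for a cyclic amine on the shorter chain changes little. Compound 3 `COCCCNC(=O)Nc1cc2c(Nc3ccc(F)c(Cl)c3)ncnc2cc1O[C@H]1CCOC1` gives 4100 nM, the highest of the three numbers; the steps of an 11-fold higher number from compound 1 to compound 3 (1.03 log units; beyond the scatter) and a 17-fold higher number from compound 2 to compound 3 (1.22 log units; beyond the scatter) show that lengthening the chain by one carbon costs a great deal.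

Compound 4 `CN(C)CCCNC(=O)Nc1cc2c(Nc3ccc(F)c(Cl)c3)ncnc2cc1O[C@H]1CCOC1` keeps the longer chain of compound 3 and differs from it in one place: dimethylamino in place of methoxy on a saturated chain carbon, three bonds along the chain from an amide-type nitrogen. Going by the values given here, the step that bears most on this is the one from compound 1 to compound 2, where an ether became an amine two bonds from the urea nitrogen and the number barely moved. Nothing measured tells whether the same holds three bonds out. The expectation is therefore a small step, a 1.6-fold lower number from compound 3 to compound 4 (0.21 log units; within the scatter), perhaps toward a slightly lower number but not clearly beyond the scatter. Compound 4 is estimated at 2500 nM in this assay, within a range from 700 nM to 9000 nM.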

Compound 4, half-maximal inhibitory concentration: 226 nM
The estimate for compound 4 lay 11-fold (1.04 log units) above the measured number; measured number outside the range, below it.
By their numbers in this assay, from the lowest: compounds 4, 2 and 1 (each within the scatter of the next); then compound 3.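

On the longer chain, the exchange of methoxy for dimethylamino matters far more than the ether-to-amine exchange on the shorter chain: the move three bonds along the chain from an amide-type nitrogen gives a large change (an 18-fold lower number from compound 3 to compound 4 (1.26 log units; beyond the scatter)), whereas the shorter-chain exchange stayed within the scatter (a 1.6-fold lower number from compound 1 to compound 2 (0.20 log units; within the scatter)). The longer chain therefore does not carry a penalty on its own in this assay, since the dimethylamino compound on that chain cannot be told apart from either shorter-chain compound (a 1.1-fold lower number from compound 2 to compound 4 (0.04 log units; within the scatter); a 1.7-fold lower number from compound 1 to compound 4 (0.23 log units; within the scatter)), and among these four compounds only compound 3, which joins the longer chain to a methoxy end, stands apart. No measurement available here accounts for this dependence of the methoxy exchange on chain length.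

From the compounds shown here alone, what stays open is whether a hydroxyl or a primary amine at the end of the chain of compound 4 would behave like the methoxy end or like the dimethylamino end. Going by these compounds, it is also open whether a still longer chain ending in dimethylamino would stay level with compound 4, or would fall away as compound 3 does.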